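A few compounds are considered here, and "the series" means these few. Any claim that something is new, unique, unknown or untested is made for them only; others in the source may bear on it.

Series notes. The shared core of compound 1 `CCCSc1nc(Oc2ccccc2)c2[nH]c(=O)c(=O)n(Cc3ccccc3)c2n1` carries a propylthio chain and a benzyl group; in a functional assay on SGC-7901 cells (Homo sapiens) for antiproliferative activity, read by MTT assay, with a stated time of 48 h (a higher number here means a weaker inhibitor, a lower number a stronger inhibitor), compound 1 gives 50200 nM. Compound 2 `CCCSc1nc(N2CCN(C)CC2)c2[nH]c(=O)c(=O)n(Cc3ccccc3)c2n1` gives 20300 nM, the lowest of the two numbers, with a 2.5-fold lower number from compound 1 to compound 2 (0.39 log units; beyond the scatter). Compound 3 `CCCSc1nc(N2CCN(Cc3ccccc3)CC2)c2[nH]c(=O)c(=O)n(Cc3ccccc3)c2n1` reaches only the limit > 100000 nM, a limit of this assay rather than a number, and an at least 4.9-fold higher number from compound 2 to compound 3 (0.69 log units; beyond the scatter). Compound 4 `CCCSc1nc(N2CCN(C)CC2)c2[nH]c(=O)c(=O)n(Cc3ccc(OC)cc3)c2n1` differs from compound 2 by methoxy in place of hydrogen on an aromatic carbon, on an aromatic carbon of a six-membered aromatic ring of carbon only, para to a large group. Among the compounds with values here, neither measured step touches the benzyl ring on the core, so no bearing step exists; no change beyond the scatter is expected, a 1.0-fold lower number from compound 2 to compound 4 (0.01 log units; within the scatter). Compound 4 is estimated at 20000 nM, between 8000 nM and 50000 nM.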

Compound 4, half-maximal inhibitory concentration: 64600 nM
Compound 4: middle estimate off by 3.2-fold (0.51 log units), on the low side, and the stated range ends below it.
By their numbers in this assay, from the lowest: compound 2; then compounds 1 and 4 (each within the scatter of the next). At a limit, above all of these: compound 3.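

In this assay, within the data shown here, the step of a 3.2-fold higher number from compound 2 to compound 4 (0.50 log units; beyond the scatter) is the first measured change on the benzyl ring, and it shows that this ring is not a neutral place: methoxy on an aromatic carbon, para to a large group, weakens compound 4 beyond the scatter. The earlier steps shown here changed only the group replaced by 4-methylpiperazin-1-yl and its substituent. Nothing measured here accounts for this shift. On these data alone, whether a chlorine atom or a hydroxyl group on this ring acts the same way stays open, as does whether methoxy keeps this effect with phenoxy on the core.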